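Aryl selenocyanate carbamates: cytotoxicity on 184B5 cells

The source may report more compounds than this note shows. Statements on the series, on what has been measured and on what is new or still open speak of the compounds shown alone.

Measured so far:
compound 1 `CCCCOC(=O)Nc1ccc([Se][Se]c2ccc(NC(=O)OCCCC)cc2)cc1`, 7200 nM
compound 2 `N#C[Se]c1ccc(NC(=O)Oc2ccccc2)cc1`, 400 nM
compound 3 `N#C[Se]c1ccc(NC(=O)Oc2ccc(Cl)cc2)cc1`, 5600 nM

In an ADME assay on 184B5 cells (Homo sapiens) for cytotoxicity, read by MTT assay, with a stated time of 72 h (a lower number here means a stronger inhibitor of growth, a higher number a weaker inhibitor of growth), compound 3 stands second highest of the three numbers. Its nearest neighbour is compound 1, whose value lies within the scatter of that of compound 3, so no order between these two is claimed. Compound 2 stands far below: a 14-fold higher number from compound 2 to compound 3 (1.15 log units; beyond the scatter).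

Compound 4 `COc1ccc(OC(=O)Nc2ccc([Se]C#N)cc2)cc1` differs from compound 3 in one place: methoxy in place of chloro on an aromatic carbon.

Among the measured compounds shown here, the only measured step on this position is the one from compound 2 to compound 3, where chloro entering in place of hydrogen gave a large rise. For the measured compounds named here, no measured step covers a methoxy at this position, so the single step bears only indirectly. It shows that substitution here can move the number strongly, but not where a methoxy would fall. An intermediate outcome between compound 2 and compound 3 is therefore expected, with the direction from compound 3 expected to be downward: a 3.1-fold lower number from compound 3 to compound 4 (0.49 log units; beyond the scatter).

For compound 4 the estimate in this assay is 1800 nM, with a range from 400 nM to 8000 nM.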

Compound 4, concentration for 50% growth inhibition: 4500 nM
For compound 4 the middle estimate is 2.5-fold (0.40 log units) below the measured one; the measured number falls inside the stated range.
By their numbers in this assay, from the lowest: compound 2; then compounds 4, 3 and 1 (each within the scatter of the next).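

In this assay, a 1.2-fold lower number from compound 3 to compound 4 (0.09 log units; within the scatter), so methoxy and chloro cannot be told apart at this position, para to a large group. The rise on leaving hydrogen is therefore not confined to chloro: an 11-fold higher number from compound 2 to compound 4 (1.05 log units; beyond the scatter), a large step beyond the scatter, as is a 14-fold higher number from compound 2 to compound 3 (1.15 log units; beyond the scatter). Among these three compounds, both substituted ones carry much higher numbers than the hydrogen compound, and none goes against this.

On these data alone, whether an amine, a carboxylic acid or a longer chain such as butoxy in the same place would also give a high number remains open, as does whether any group replacing hydrogen here would do so. Nothing available explains why the number moves at this position.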